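Working notes: 2,4-dichlorophenyl in place of phenyl on ring nitrogen

The source may hold more compounds than are shown below. What is called first, only, known or untested is meant among the compounds shown, and "the series" means these compounds.

Three members of the series have been measured in a functional assay on K562 cells (Homo sapiens) for antiproliferative activity, read by MTT assay, with a stated time of 72 h; a lower number here means a stronger inhibitor, a higher number a weaker inhibitor. Compound 1 `COc1cc(-n2ncnc2-c2cccc([N+](=O)[O-])c2)cc(OC)c1OC` gives only a limit of the assay, > 10000 nM. Compound 2 `COc1ccccc1-c1ncnn1-c1cc(OC)c(OC)c(OC)c1` likewise returns only a limit, > 10000 nM. Compound 3 `COc1cc(-c2ncnn2-c2ccccc2)cc(OC)c1OC`, the starting point of the present step, also sits at a limit, > 10000 nM. Compound 3 therefore stands nowhere distinguishable from the others: every value shown is a limit, and the limit of > 10000 nM in this assay, at which 3 of the 3 values shown sit, sums up the whole measured set. Within the data shown here, no step between measured compounds can be sized, so the effect of any structural change in this assay is so far unknown.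

Compound 4 `COc1cc(-c2ncnn2-c2ccc(Cl)cc2Cl)cc(OC)c1OC` is not yet measured. It differs from compound 3 in one place: 2,4-dichlorophenyl in place of phenyl on an aromatic nitrogen. With only a limit known for compound 3, neither a gain of some size nor another limit can be excluded for compound 4. Lacking any measured step to lean on, the expected change in this assay is a number no higher from compound 3 to compound 4 (the limit leaves the size open), its direction open and another limit the most likely outcome. Compound 4 is accordingly estimated at 10000 nM, within the range 3000 nM to 30000 nM.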

Compound 4, half-maximal inhibitory concentration: > 10000 nM
Compound 4: no number, only a limit; the forecaster's own chance of this, stated with the estimate: 65%; the middle value sits exactly at the limit.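

Compound 4 gives > 10000 nM in this assay as a limit of the assay, not a number. Among these compounds, compound 3 also sits at a limit, so no step between compound 3 and compound 4 can be read. The compounds shown leave open whether any member of the series gives a readable number, and what any single change on the shared core does to antiproliferative activity.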